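The compounds below may be only part of what the source reports. "The series", "measured", "known", "first", "only" and "open" are said of these compounds alone.

Compound 1 `COc1cc2c(Oc3ccc(NC(=O)c4cn(-c5c(C)cccc5C)nn4)cc3F)ccnc2cc1OCCCN1CCCCC1` gives in a functional assay on HT-29 cells (Homo sapiens) for cytotoxicity, read by MTT assay, with a stated time of 72 h (on this read-out lower numbers stand for stronger inhibition and higher numbers for weaker inhibition), a value of 3690 nM, the highest of the two numbers recorded here. Within the data shown here, the only other measured compound, compound 2 `COc1cc2c(Oc3ccc(NC(=O)c4cn(-c5ccc(F)c(F)c5)nn4)cc3F)ccnc2cc1OCCCN1CCCCC1`, gives in this assay a value of 210 nM; that step, an 18-fold lower number from compound 1 to compound 2 (1.24 log units; beyond the scatter), comes from a 3,4-difluorophenyl in place of 2,6-dimethylphenyl on an aromatic nitrogen. Compound 3 `COc1cc2c(Oc3ccc(NC(=O)c4cn(-c5c(C)cccc5C)nn4)cc3F)ccnc2cc1OCCCN1CCC(C)CC1` keeps the 2,6-dimethylphenyl of compound 1 and differs from it only by methyl in place of hydrogen on a saturated ring carbon, on a saturated ring carbon of a six-membered non-aromatic ring with one nitrogen, three ring bonds from the ring nitrogen. Among the measured compounds shown here, no measured step touches this ring: the single recorded step concerns a different part of the shared core, so nothing here bears directly on the change. Without guidance either way, compound 3 is expected to show no step beyond the scatter, a 1.0-fold higher number from compound 1 to compound 3 (0.00 log units; within the scatter). Compound 3 is therefore estimated at 3700 nM, within a range of 1500 nM to 9000 nM.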

Compound 3, half-maximal inhibitory concentration: 2450 nM
Compound 3: the middle estimate sits 1.5-fold (0.18 log units) above what was measured; the measured number falls inside the stated range.
By their numbers in this assay, from the lowest: compound 2; then compounds 3 and 1 (each within the scatter of the next).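

In this assay the change from piperidin-1-yl to 4-methylpiperidin-1-yl gives a 1.5-fold lower number from compound 1 to compound 3 (0.18 log units; within the scatter) and so does not separate compound 3 from compound 1. Among these compounds, this is the first measured step on the six-membered non-aromatic ring, and a single methyl three ring bonds from the ring nitrogen stays within the scatter, whereas the change on the aromatic nitrogen gave an 18-fold lower number from compound 1 to compound 2 (1.24 log units; beyond the scatter) and lies beyond it. No measurement at hand accounts for this result.

Going by these compounds, whether a hydroxyl, an amine or a phenyl on this ring carbon would also stay within the scatter remains open. So does whether the methyl would give the same result alongside the 3,4-difluorophenyl of compound 2.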